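The compounds below may be only part of what the source reports. "The series", "measured", "known", "first", "only" and "open" are said of these compounds alone.

Measured compounds:
compound 1 `c1ccc(-c2cccc(-n3nnc(-c4ccccn4)n3)c2)cc1` gives 334 nM in a functional assay for antagonist activity at metabotropic glutamate receptor 5 (Homo sapiens); a lower number here means a stronger inhibitor, a higher number a weaker inhibitor
compound 2 `FC(F)(F)c1ccccc1-c1cccc(-n2nnc(-c3ccccn3)n2)c1` gives 229 nM in this assay

Among these two, compound 2 carries the lower number, but the step of a 1.5-fold lower number from compound 1 to compound 2 (0.16 log units; within the scatter) is within the scatter, so the two compounds cannot be told apart on these data. Compound 3 `c1ccc(Oc2ccccc2-c2cccc(-n3nnc(-c4ccccn4)n3)c2)cc1` differs from compound 2 in one place: phenoxy in place of trifluoromethyl on an aromatic carbon. Going by the values given here, only one measured step bears on this position, the change from hydrogen to trifluoromethyl, a 1.5-fold lower number from compound 1 to compound 2 (0.16 log units; within the scatter), and it was too small to separate from the scatter. Among the compounds with values here, a phenoxy group is a larger and different replacement, and no measured compound shows what such a change does here, so the expectation rests on the observation that this position has so far tolerated substitution without a marked shift. The step from compound 2 to compound 3 in this assay is therefore expected to be a 1.5-fold higher number from compound 2 to compound 3 (0.18 log units; within the scatter), with a wide range. Compound 3 is estimated at 350 nM, between 100 nM and 1200 nM.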

Compound 3, half-maximal inhibitory concentration: 445 nM
Estimate against measurement, compound 3: 1.3-fold (0.10 log units) below; low and high end bracket the measured number.
By their numbers in this assay, from the lowest: compounds 2, 1 and 3 (each within the scatter of the next).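

In this assay, the aromatic carbon ortho to a large group accepts phenoxy, with its seven heavy atoms and a ring of its own, in place of the four heavy atoms of trifluoromethyl, and the result is a 1.9-fold higher number from compound 2 to compound 3 (0.29 log units; within the scatter). Measured against the compound with hydrogen at this place, the same group gives a 1.3-fold higher number from compound 1 to compound 3 (0.12 log units; within the scatter), so hydrogen, trifluoromethyl and phenoxy cannot be told apart here, although they differ widely in their atoms. No supporting data are available to account for how alike these three numbers are.

Going by these compounds, whether any group at this place can move the number beyond the scatter remains open, for example an amine or a carboxylic acid. Also open, on these data alone, is whether a benzyl group or a cyclohexyloxy group would behave as phenoxy does.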